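The source may report more compounds than this note shows. Statements on the series, on what has been measured and on what is new or still open speak of the compounds shown alone.

Measured in a functional assay on MIA PaCa-2 cells (Homo sapiens) for inhibition, read by MTT assay, with a stated time of 4 days; on this read-out higher numbers stand for weaker inhibition and lower numbers for stronger inhibition:
Compound 1 `COc1cc(NC(C)CCCNC(=O)NN)c2ncccc2c1`: >= 250000 nM (a limit)
Compound 2 `COc1cc(NC(C)CCCNC(=O)NNC(=O)NCCCO)c2ncccc2c1`: >= 250000 nM (a limit)

Compound 2 stands only at a limit, and no number is known for it. Going by the values given here, the whole series so far rests on (the limit of >= 250000 nM in this assay, at which 2 of the 2 values shown sit). Among the compounds with values here, the only measured step is a step that the two limits leave unreadable from compound 1 to compound 2, so it offers no size to carry forward.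

The next compound is compound 3 `COc1cc(NC(C)CCCNC(=O)Nc2ccc(Cl)c(C(F)(F)F)c2)c2ncccc2c1`. Its difference from compound 2 is 4-chloro-3-(trifluoromethyl)phenyl in place of ((3-hydroxypropyl)carbamoyl)amino on an amide-type nitrogen. The group that enters brings one six-membered aromatic ring of carbon only onto the amide-type nitrogen, and neither measured compound carries such a group there. Within the data shown here, no measured step therefore bears directly on this change. Compound 2, with its limit of >= 250000 nM, leaves room in only one direction, so the expected step in this assay is toward stronger inhibition. The estimated change is an at least 16-fold lower number from compound 2 to compound 3 (1.22 log units; beyond the scatter), and its size is a judgement from the structural change alone. Compound 3 is expected at about 15000 nM, with an estimated range from 3000 nM to 80000 nM.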

Compound 3, half-maximal inhibitory concentration: 4000 nM
Estimate against measurement, compound 3: 3.8-fold (0.57 log units) above; the measured number falls inside the stated range.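

In this assay, going by these compounds alone, compound 3 gives 4000 nM, the first number that is not a limit, and so the amide-type nitrogen proves to be a place where a change of group can move the read-out. Setting 4-chloro-3-(trifluoromethyl)phenyl there in place of ((3-hydroxypropyl)carbamoyl)amino gives an at least 62-fold lower number from compound 2 to compound 3 (1.79 log units; beyond the scatter), and setting it in place of amino gives an at least 62-fold lower number from compound 1 to compound 3 (1.79 log units; beyond the scatter), so two quite different groups on this nitrogen are both left far behind by the one group that brings a six-membered aromatic ring of carbon only. Both steps start from a limit, so each fixes only the smallest possible size and the true size stays unknown: the limit of >= 250000 nM in this assay, at which 2 of the 3 values shown sit.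

Whether the ring alone accounts for the change stays open, as a plain phenyl, a 4-chlorophenyl or a saturated cyclohexyl on the amide-type nitrogen would be needed to separate the ring from its chlorine and trifluoromethyl groups. Also open, going by these compounds, is how a shorter or longer chain in the shared core would act alongside the 4-chloro-3-(trifluoromethyl)phenyl group.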